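Trimming the amide of compound 1

A few compounds are considered here, and "the series" means these few. Any claim that something is new, unique, unknown or untested is made for them only; others in the source may bear on it.

Within the data shown here, in a functional assay on the whole organism with Mus musculus as the target (on this read-out lower numbers stand for an effect already at smaller amounts and higher numbers for an effect only at larger amounts of compound), compound 1 `CCN(C)C(=O)/C=C1\CCc2c(F)cc(F)cc21` gives 56 mg/kg, the lowest of the three numbers measured so far. Compound 2 `C/C(=C\C(=O)NC1CC1)c1cccc(F)c1` gives 122 mg/kg and compound 3 `O=C(/C=C1\CCc2ccccc21)NC1CC1` gives 150 mg/kg, both higher by more than the usual scatter. Still unmeasured is compound 4 `CNC(=O)/C=C1\CCc2c(F)cc(F)cc21`, which differs from compound 1 in one place: hydrogen in place of ethyl on an amide-type nitrogen, with hydrogen in place of ethyl on an amide-type nitrogen.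

Among the measured compounds shown here, no two measured compounds differ in only one place, so nothing yet measures this change directly. The only hint is weak: compound 2 at 122 mg/kg and compound 3 at 150 mg/kg also carry a hydrogen on the amide-type nitrogen, but both differ from compound 1 elsewhere too. A modest upward step in this assay, about as large as the usual scatter, is therefore expected, a 1.8-fold higher number from compound 1 to compound 4 (0.25 log units; within the scatter). For compound 4 the estimated value is 100 mg/kg, with an expected range from 45 mg/kg to 220 mg/kg.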

Compound 4, dose for half-maximal effect: 45 mg/kg
The estimate for compound 4 lay 2.2-fold (0.35 log units) above the measured number, and the stated range covers the measured number.
By their numbers in this assay, from the lowest: compounds 4 and 1 (each within the scatter of the next); then compounds 2 and 3 (each within the scatter of the next).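

Among these compounds, this gives the first direct reading of the amide nitrogen: in this assay, hydrogen in place of ethyl gives a 1.2-fold lower number from compound 1 to compound 4 (0.09 log units; within the scatter). With the core held fixed, the ethyl group can therefore be removed from this nitrogen without a shift that stands clear of repeat measurements, and the methyl group that remains is enough to keep the number in the same range. Nothing available explains why the two compounds read alike.

Still open, on these data alone, is whether this nitrogen accepts something other than these small groups, such as a benzyl group or a longer chain ending in an amine or a carboxylic acid. Also open, as far as these compounds go, is whether the same change would read alike on the core of compound 3, and what would happen if the methyl group were replaced by hydrogen as well.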